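A few compounds are considered here, and "the series" means these few. Any claim that something is new, unique, unknown or untested is made for them only; others in the source may bear on it.

In a functional assay on the whole organism with Rattus norvegicus as the target (a higher number here means that more compound is needed for the effect, a lower number that less compound is needed), compound 1 `CCC(C)Oc1ccccc1-c1ncc(-c2nn[nH]n2)c(O)n1` gives 0.05 mg/kg and compound 2 `C=CCOc1ccccc1-c1ncc(-c2nn[nH]n2)c(O)n1` gives 0.24 mg/kg, so compound 2 holds the higher of the two numbers, and more of it is needed for the effect. The next compound is compound 3 `Oc1nc(-c2ccccc2OCC2CC2)ncc1-c1nn[nH]n1`, which differs from compound 2 as follows: cyclopropyl in place of vinyl on a saturated chain carbon bound to an oxygen on an aromatic ring. In other words, cyclopropyl stands in place of vinyl on a saturated chain carbon bound to an oxygen on an aromatic ring, turning allyloxy into cyclopropylmethoxy. Among the measured compounds shown here, only one measured step bears on this change: a 4.8-fold higher number from compound 1 to compound 2 (0.68 log units; beyond the scatter), with allyl in place of sec-butyl. For the measured compounds named here, no measured compound carries a cyclopropyl group, so this guide is indirect. Compound 3, like compound 1, has no vinyl, so it is expected to fall part of the way back towards compound 1. The expected move in this assay is toward a lower number, a 2.2-fold lower number from compound 2 to compound 3 (0.34 log units; beyond the scatter). For compound 3 the estimated value is 0.11 mg/kg, with an expected range from 0.04 mg/kg to 0.3 mg/kg.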

Compound 3, dose for 50% inhibition: 0.07 mg/kg
For compound 3 the middle estimate is 1.6-fold (0.20 log units) above the measured one; the range from low to high includes it.
By their numbers in this assay, from the lowest: compounds 1 and 3 (each within the scatter of the next); then compound 2.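

In this assay, cyclopropyl in place of vinyl on a saturated chain carbon bound to an oxygen on an aromatic ring gives a 3.4-fold lower number from compound 2 to compound 3 (0.54 log units; beyond the scatter), so this position accepts a small carbon ring and the number does not depend on keeping the double bond of allyl. Cyclopropylmethyl in place of sec-butyl on the same oxygen gives a 1.4-fold higher number from compound 1 to compound 3 (0.15 log units; within the scatter), so this assay does not separate these two groups. Among the three compounds, allyl alone stands apart, with compound 2 needing more compound than either of the others.

No evidence accompanies these numbers to account for the difference. The compounds shown leave open how a cyclobutylmethyl group, a longer chain such as n-pentyl, or an amine in the chain on this oxygen would read.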